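Changing the Aryl Group on a Shared Core: Cytotoxicity Outlook

The compounds below may be only part of what the source reports. "The series", "measured", "known", "first", "only" and "open" are said of these compounds alone.

Compound 1 `O=c1oc2ccccc2c2nc3c(ccc4cc[nH]c43)c(-c3ccc(Br)cc3)c12`: 70700 nM
Compound 2 `O=c1oc2ccccc2c2nc3c(ccc4cc[nH]c43)c(-c3cccnc3Cl)c12`: 70700 nM
Compound 3 `O=c1cc(O)c2cc(Cl)ccc2o1`: 70700 nM

These values come from a functional assay on B16-F10 cells (Mus musculus) for cytotoxicity; a lower number here means a stronger inhibitor, a higher number a weaker inhibitor. Compound 2 stands level with compounds 1 and 3 at the digits shown; its nearest neighbour is compound 1 and its furthest is compound 3, and neither gap exceeds the scatter of repeated measurements. Compound 4 `O=c1oc2ccccc2c2nc3c(ccc4cc[nH]c43)c(-c3ccccn3)c12` differs from compound 2 in one place: pyridin-2-yl in place of 2-chloropyridin-3-yl on an aromatic carbon. Going by the values given here, the only measured step that bears on this change is no change at the digits printed from compound 1 to compound 2 (within the scatter), in which one aromatic ring replaced another at the same position and the value stayed put. On that basis no step beyond the scatter is expected; the estimated step is no change at the digits printed from compound 2 to compound 4 (within the scatter). For compound 4 the expected value in this assay is 70700 nM, with a range from 30000 nM to 100000 nM.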

Compound 4, half-maximal inhibitory concentration: 70700 nM
Compound 4: the middle estimate sits on the measured number at the digits printed, within the range that was stated.
By their numbers in this assay, from the lowest: compounds 1, 2, 3 and 4 (each within the scatter of the next).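

In this assay, replacing 2-chloropyridin-3-yl with pyridin-2-yl gives no change at the digits printed from compound 2 to compound 4 (within the scatter), and replacing 4-bromophenyl with pyridin-2-yl gives no change at the digits printed from compound 1 to compound 4 (within the scatter). The earlier aromatic groups at this position both carried a halogen, whereas this one carries none, and the number still holds, so losing the halogen leaves the read-out unmoved in these compounds. Nothing measured here explains this flat result. Still open, as far as these compounds go, is whether a non-aromatic group at this position, such as an amine, a carboxylic acid or a longer alkyl chain, would shift the value.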